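Acetyl for hydrogen on the ring oxygen of compound 2

This account rests on a few compounds, and the source may have more. Where it says the series, first, only, none or still open, it means among the compounds named here.

Measured compounds in an assay on isolated protein for inhibition of Amine oxidase [flavin-containing] A (Homo sapiens), read by fluorescence and spectrophotometry, with a stated time of 20 min; on this read-out higher numbers stand for weaker inhibition and lower numbers for stronger inhibition: compound 1 `N#Cc1cc2cc(-c3ccccc3)n(O)c2cc1C#N`, 6920 nM; compound 2 `N#Cc1cc2cc(-c3cccs3)n(O)c2cc1C#N`, 11100 nM.

Compound 2 sits within the scatter of compound 1, as the step of a 1.6-fold higher number from compound 1 to compound 2 (0.21 log units; within the scatter) shows. Compound 3 `CC(=O)On1c(-c2cccs2)cc2cc(C#N)c(C#N)cc21` differs from compound 2 by acetyl in place of hydrogen on an oxygen on an aromatic ring. For the measured compounds named here, no measured step bears on this change; the only step known concerns thiophen-2-yl in place of phenyl, not the oxygen. With nothing to go on, compound 3 is expected to stay near compound 2, a step of a 1.3-fold higher number from compound 2 to compound 3 (0.10 log units; within the scatter), and its estimated value in this assay is 14000 nM, ranging from 3500 nM to 56000 nM.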

Compound 3, half-maximal inhibitory concentration: 2080 nM
For compound 3 the middle estimate is 6.7-fold (0.83 log units) above the measured one; measured number below the stated range.
By their numbers in this assay, from the lowest: compound 3; then compounds 1 and 2 (each within the scatter of the next).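

In this assay, acetyl in place of hydrogen on the oxygen on an aromatic ring gives a 5.3-fold lower number from compound 2 to compound 3 (0.73 log units; beyond the scatter) and lies beyond the scatter. This oxygen is therefore a place where a change moves the read-out toward stronger inhibition, which the swap of thiophen-2-yl for phenyl did not show. No available evidence explains this step.

On these data alone, whether a longer chain such as propanoyl, or a methyl group, on the same oxygen would do the same stays open. So does whether acetyl on compound 1 would give a similar step.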